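This account rests on a few compounds, and the source may have more. Where it says the series, first, only, none or still open, it means among the compounds named here.

Measured compounds in the series:

- compound 1, `COc1ccccc1NC(=O)c1cc2ccccc2oc1=O`: 35400 nM
- compound 2, `Cc1ccccc1NC(=O)c1cc2cc(Br)cc(Br)c2oc1=O`: 4680 nM

Both numbers come from an assay for inhibition of Amine oxidase [flavin-containing] B (Homo sapiens), read by fluorescence, using microsomes, with a stated time of 15 min; a higher number here means a weaker inhibitor, a lower number a stronger inhibitor. Compound 2 holds the lower of the two values, and the gap to compound 1 lies beyond the scatter of the method. For the measured compounds named here, the two compounds differ in more than one place, so no single structural step between them can be read from these two values.

The next compound, compound 3, `COc1ccccc1NC(=O)c1cc2cc(Br)cc(Br)c2oc1=O`, is still to be measured in this assay. It is derived from compound 2 by one change: methoxy in place of methyl on an aromatic carbon. The resulting anilide ring carries the same methoxy group seen in compound 1, while the two bromines of compound 2 are kept.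

Going by the values given here, no measured pair isolates this exchange, so the direction of the step is not known from the data. Compound 1, which carries the methoxy group, gives the higher number of the two, but its missing bromines prevent any clean attribution. For compound 3 a step close to none beyond the scatter is expected, with a modest lean toward a higher number, a 1.4-fold higher number from compound 2 to compound 3 (0.14 log units; within the scatter). The estimated value for compound 3 in this assay is 6500 nM, within a range of 2000 nM to 22000 nM.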

Compound 3, half-maximal inhibitory concentration: 20200 nM
Compound 3: middle estimate off by 3.1-fold (0.49 log units), on the low side; the range from low to high includes it.
By their numbers in this assay, from the lowest: compound 2; then compounds 3 and 1 (each within the scatter of the next).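

In this assay, for the compounds shown here, the exchange of 2-methylphenyl for 2-methoxyphenyl gives the first reading that isolates this position: a 4.3-fold higher number from compound 2 to compound 3 (0.64 log units; beyond the scatter), with the two bromines and the rest of the core held constant. The place on the aromatic carbon ortho to a large group is therefore not indifferent to what it carries, and with both bromines present, methoxy gives a higher number than methyl, leaving compound 2 at 4680 nM as the lower member of this pair. No measurement beyond these inhibition values accompanies the step, so the data offer no explanation for its direction or size.

Going by these compounds, this single step comes from one background, and the effect of the two bromines cannot be read, so it remains open whether methoxy in place of methyl would give a step of similar direction and size on the core without them. On these data alone, it is also open how this position would respond to a hydrogen, a chlorine, an ethyl group or an amine, which would show whether methyl stands out or simply lies along a wider trend.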